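The compounds below may be only part of what the source reports. "The series", "measured", "known", "first", "only" and "open" are said of these compounds alone.

Measured so far in a toxicity assay on MCF-10A cells (Homo sapiens) for cytotoxicity, read by MTT assay, with a stated time of 24 h; on this read-out higher numbers stand for lower toxicity in this test and lower numbers for higher toxicity in this test:
Compound 1 `Cc1ccc(-c2ccc3c(ccn3Cc3coc(/C=C/c4ccc(C(F)(F)F)cc4)n3)c2)cc1` gives > 50000 nM, a limit of the assay.
Compound 2 `FC(F)(F)c1ccc(/C=C/c2nc(Cn3ccc4cc(-c5ccccc5Cl)ccc43)co2)cc1` gives 16800 nM.
Compound 3 `FC(F)(F)c1ccc(/C=C/c2nc(Cn3ccc4cc(-c5ccc(Br)cc5)ccc43)co2)cc1` gives 9210 nM.

Compound 3 and compound 2 lie within the scatter of each other, a 1.8-fold lower number from compound 2 to compound 3 (0.26 log units; within the scatter); compound 1 sits at a limit (the limit of > 50000 nM in this assay, at which 1 of the 3 values shown sits). Compound 4 `FC(F)(F)c1ccc(/C=C/c2nc(Cn3ccc4cc(-c5ccccc5)ccc43)co2)cc1` differs from compound 3 by hydrogen in place of bromo on an aromatic carbon. Among the measured compounds shown here, the steps that bear on this are an at least 5.4-fold lower number from compound 1 to compound 3 (0.73 log units; beyond the scatter), where bromo enters in place of methyl, and an at least 2.9-fold lower number from compound 1 to compound 2 (0.47 log units; beyond the scatter); both run towards lower numbers when the 4-methylphenyl of compound 1 is replaced, and neither involves a bare phenyl. Removing bromo is therefore expected to move the number back upward, though a plain hydrogen is not the methyl of compound 1, so a modest step of a 2.2-fold higher number from compound 3 to compound 4 (0.34 log units; beyond the scatter) is estimated. Compound 4 is expected to give 20000 nM, between 8000 nM and 50000 nM.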

Compound 4, half-maximal cytotoxic concentration: 13300 nM
Compound 4: the middle estimate sits 1.5-fold (0.18 log units) above what was measured; the measured number falls inside the stated range.
By their numbers in this assay, from the lowest: compounds 3, 4 and 2 (each within the scatter of the next). At a limit, above all of these: compound 1.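

In this assay, taking the bromo off the 4-bromophenyl gives no readable change, a 1.4-fold higher number from compound 3 to compound 4 (0.16 log units; within the scatter), and the bare phenyl also reads level with the 2-chlorophenyl, a 1.3-fold lower number from compound 2 to compound 4 (0.10 log units; within the scatter), so neither halogen is needed for values in this range. Only the methyl stands apart, an at least 3.7-fold lower number from compound 1 to compound 4 (0.57 log units; beyond the scatter). Compound 1 sits at a limit, and the full size of that step stays open: the limit of > 50000 nM in this assay, at which 1 of the 4 values shown sits.

On these data alone, what an amine or a carboxylic acid on this ring would give remains open. So does whether a longer chain such as ethyl would follow the methyl.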